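Pyridin-2-yl for 3-(4-fluorophenyl)propyl in compound 3

A few compounds are considered here, and "the series" means these few. Any claim that something is new, unique, unknown or untested is made for them only; others in the source may bear on it.

Compound 3 `Nc1nc(N2CCN(C(=O)COc3ccc(Cl)cc3)CC2)c2nc(CCCc3ccc(F)cc3)sc2n1` gives 960 nM in a functional assay on cells (Lymphocyte, Homo sapiens) (a lower number here means a stronger inhibitor, a higher number a weaker inhibitor), the highest of the two numbers in hand. Compound 2 `Nc1nc(N2CCN(C(=O)COc3ccccc3)CC2)c2nc(-c3ccc(F)cc3)sc2n1` gives 90 nM in this assay. Compound 1 `CC(C)(Oc1ccc(Cl)cc1)C(=O)N1CCN(c2nc(N)nc3sc(-c4ccc(F)cc4)nc23)CC1` reaches only the limit of > 10000 nM in this assay. Compound 4 `Nc1nc(N2CCN(C(=O)COc3ccc(Cl)cc3)CC2)c2nc(-c3ccccn3)sc2n1` carries pyridin-2-yl in place of 3-(4-fluorophenyl)propyl on an aromatic carbon. Among the measured compounds shown here, the one measured step, an at least 110-fold lower number from compound 1 to compound 2 (2.04 log units; beyond the scatter), alters the group on the carbonyl carbon and does not touch the ring carbon changed here; compounds 2 and 3 differ in two places at once, so their gap cannot be assigned to either. Compound 4 again carries an aromatic ring directly on the five-membered ring, as does compound 2 at 90 nM. For compound 4 a lower number is therefore expected, a 4.8-fold lower number from compound 3 to compound 4 (0.68 log units; beyond the scatter). Compound 4 is estimated at 200 nM, within 50 nM to 800 nM.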

Compound 4, half-maximal inhibitory concentration: 230 nM
Beside the measured number, compound 4's estimate is 1.2-fold (0.06 log units) below it; the range from low to high includes it.
By their numbers in this assay, from the lowest: compound 2; then compound 4; then compound 3. At a limit, above all of these: compound 1.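

In this assay, pyridin-2-yl in place of 3-(4-fluorophenyl)propyl gives a 4.2-fold lower number from compound 3 to compound 4 (0.62 log units; beyond the scatter), so the group on this aromatic carbon of the five-membered ring moves the number with the rest of the molecule held fixed. The earlier readable step touched only the group on the carbonyl carbon, and the 3-(4-fluorophenyl)propyl chain is now shown not to be needed for a value in this range. Nothing measured here bears on why the number falls.

Compounds 2 and 4 differ in two places, so their gap cannot be read. Open, going by these compounds, is how an amine or a morpholine ring on this aromatic carbon would compare with pyridin-2-yl.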